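A few compounds are considered here, and "the series" means these few. Any claim that something is new, unique, unknown or untested is made for them only; others in the source may bear on it.

Of the compounds shown here, three have so far been tested in a functional assay on the whole organism (strain NMRI) with Mus musculus as the target, with a stated time of 4 h; on this read-out higher numbers stand for an effect only at larger amounts of compound and lower numbers for an effect already at smaller amounts. Compound 1, with the structure `COc1ccc(Cn2cc(CO/N=C/c3c(-c4ccc(C)cc4)nc4ccc(Br)cn34)nn2)cc1`, gives 40 mg/kg. Compound 2, with the structure `Cc1ccc(-c2nc3ccc(Br)cn3c2/C=N/OCc2cn(Cc3ccc(C#N)cc3)nn2)cc1`, gives 40 mg/kg. Compound 3, with the structure `COc1ccc(Cn2cc(CO/N=C/c3c(-c4ccccc4)nc4ccc(Br)cn34)nn2)cc1`, gives 40 mg/kg. On these numbers compound 3 stands level with the other two: the step of no change at the digits printed from compound 1 to compound 3 (within the scatter) lies within the scatter, and so does the step of no change at the digits printed from compound 1 to compound 2 (within the scatter).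

Compound 4, with the structure `N#Cc1ccc(Cn2cc(CO/N=C/c3c(-c4ccccc4)nc4ccc(Br)cn34)nn2)cc1`, has not yet been measured. It differs from compound 3 in one place: cyano in place of methoxy on an aromatic carbon. This exchange, a cyano in place of a methoxy on an aromatic carbon, has been seen once before on a core that still carried the methyl group, and there the step of no change at the digits printed from compound 1 to compound 2 (within the scatter) shows no movement beyond the scatter. Among the compounds with values here, the only other measured step, no change at the digits printed from compound 1 to compound 3 (within the scatter), concerns the methyl itself and also stays within the scatter. Nothing among these three compounds points to a shift in this assay from this exchange. The expected outcome is the step of no change at the digits printed from compound 3 to compound 4 (within the scatter), that is, no change beyond the scatter. Compound 4 is therefore estimated to give 40 mg/kg, with a range from 20 mg/kg to 80 mg/kg.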

Compound 4, minimum effective dose: 20 mg/kg
The estimate for compound 4 lay 2.0-fold (0.30 log units) above the measured number, and the stated range covers the measured number.
By their numbers in this assay, from the lowest: compounds 4, 1, 2 and 3 (each within the scatter of the next).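

Compound 4 lets the cyano-for-methoxy exchange, 4-methoxybenzyl to 4-cyanobenzyl, be read on a second core in this assay. There it gives a 2.0-fold lower number from compound 3 to compound 4 (0.30 log units; within the scatter), and the two readings agree: the same change on two cores in this assay, no change at the digits printed (within the scatter) from compound 1 to compound 2 and a 2.0-fold lower number (0.30 log units; within the scatter) from compound 3 to compound 4, 2.0-fold (0.30 log units) apart, within the scatter of two such steps Compound 4 also lets the exchange of hydrogen for methyl on an aromatic carbon be read with the 4-cyanobenzyl group in place of the 4-methoxybenzyl group, giving a 2.0-fold lower number from compound 2 to compound 4 (0.30 log units; within the scatter), and these two readings agree as well: the same change on two cores in this assay, no change at the digits printed (within the scatter) from compound 1 to compound 3 and a 2.0-fold lower number (0.30 log units; within the scatter) from compound 2 to compound 4, 2.0-fold (0.30 log units) apart, within the scatter of two such steps Each exchange has therefore now been read in two settings, and all four of these steps stay inside the usual scatter, so neither place has yet shown a clear effect on this read-out.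

The compounds shown leave open whether any group on this benzyl ring can move the reading beyond the scatter, for example an amine, a carboxylic acid or a longer chain in place of the methoxy or cyano. They also leave open what happens when the bromine on the shared core is exchanged, since all four compounds carry it.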